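The source may report more compounds than this note shows. Statements on the series, on what has been measured and on what is new or still open speak of the compounds shown alone.

Compound 3 `CCOC(=O)c1c(-c2cccc(C)c2)[nH]c2cc(OC)ccc2c1=O` gives 48000 nM in a physicochemical assay for solubility, in phosphate buffer, at pH 7.4 (on this read-out lower numbers stand for lower solubility and higher numbers for higher solubility), the highest of the two numbers in hand; compound 2 `CCOC(=O)c1c(-c2ccc(Cl)cc2)[nH]c2cc(OC)ccc2c1=O` gives 3000 nM, and the step of a 16-fold higher number from compound 2 to compound 3 (1.20 log units; beyond the scatter) separates them. Compound 1 `CCOC(=O)c1c(-c2cccc(F)c2)[nH]c2cc(OC)ccc2c1=O` sits at a limit in this assay, > 100000 nM, as noted in the limit of > 100000 nM in this assay, at which 1 of the 3 values shown sits. Compound 4 `CCOC(=O)c1c(-c2ccccc2Cl)[nH]c2cc(OC)ccc2c1=O` is not yet measured; it carries the change (2-chlorophenyl in place of 3-methylphenyl on an aromatic carbon). The two steps that bear on it both involve a chlorophenyl group: an at least 33-fold lower number from compound 1 to compound 2 (1.52 log units; beyond the scatter) and a 16-fold higher number from compound 2 to compound 3 (1.20 log units; beyond the scatter), each large and each with the chlorophenyl on the low side. A return of chlorine, now as 2-chlorophenyl, is therefore expected to lower the number by less than a full reversal, so that the expected step is a 4.8-fold lower number from compound 3 to compound 4 (0.68 log units; beyond the scatter). Compound 4 is estimated at 10000 nM, within 3000 nM to 35000 nM.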

Compound 4, solubility: 28000 nM
Compound 4: middle estimate off by 2.8-fold (0.45 log units), on the low side, and the stated range covers the measured number.
By their numbers in this assay, from the lowest: compound 2; then compounds 4 and 3 (each within the scatter of the next). At a limit, above all of these: compound 1.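

Chlorine alone does not bring the low number: 2-chlorophenyl in place of 4-chlorophenyl gives a 9.3-fold higher number from compound 2 to compound 4 (0.97 log units; beyond the scatter), so among the compounds shown the low value goes with the 4-chlorophenyl of compound 2 only. The 2-chlorophenyl and 3-methylphenyl groups are not told apart, with a 1.7-fold lower number from compound 3 to compound 4 (0.23 log units; within the scatter). The step of an at least 3.5-fold lower number from compound 1 to compound 4 (0.55 log units; beyond the scatter) is only a bound, as compound 1 stands at a limit: the limit of > 100000 nM in this assay, at which 1 of the 4 values shown sits.

Still open, as far as these compounds go, is how a 3-chlorophenyl or a phenyl carrying an amine would read at this carbon. Also open, from the compounds shown here alone, is what a carboxylic acid in place of the ethoxycarbonyl group would do to the number.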